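Cyclopentyl to methoxy on the carbonyl carbon of compound 3

A few compounds are considered here, and "the series" means these few. Any claim that something is new, unique, unknown or untested is made for them only; others in the source may bear on it.

Compound 1 `Cc1cc(C(=O)Nc2ccccc2)nn1Cc1cc(Cl)ccc1OCc1ccccc1` gives 39.8 nM in an assay on CHO-K1 cells for displacement of a labelled ligand from prostaglandin E2 receptor EP1 subtype (Homo sapiens); on this read-out lower numbers stand for stronger inhibition and higher numbers for weaker inhibition.
Compound 2 `Cc1cc(C(=O)Nc2ccc(F)cc2)nn1Cc1cc(Cl)ccc1OCc1ccccc1` gives 79.4 nM in this assay.
Compound 3 `Cc1cc(NC(=O)C2CCCC2)nn1Cc1cc(Cl)ccc1OCc1ccccc1` gives 15.9 nM in this assay.

Compound 3 stands lowest of the three, with a 2.5-fold lower number from compound 1 to compound 3 (0.40 log units; beyond the scatter) and a 5.0-fold lower number from compound 2 to compound 3 (0.70 log units; beyond the scatter); both steps are beyond the scatter, so compound 3 is the strongest measured member. Compound 4 `COC(=O)Nc1cc(C)n(Cc2cc(Cl)ccc2OCc2ccccc2)n1` is not yet measured. It differs from compound 3 by methoxy in place of cyclopentyl on a carbonyl carbon. Among the measured compounds shown here, no measured step bears on this change: the two measured steps alter the phenylcarbamoyl or (4-fluorophenyl)carbamoyl group and the amide direction, not the cyclopentyl itself. The step from compound 3 to compound 4 is therefore unsupported by precedent, and a modest rise in the number is expected. Compound 4 is estimated at 50 nM, within 15 nM to 160 nM, which is a step of a 3.1-fold higher number from compound 3 to compound 4 (0.50 log units; beyond the scatter).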

Compound 4, half-maximal inhibitory concentration: 200 nM
For compound 4 the middle estimate is 4.0-fold (0.60 log units) below the measured one, outside the stated range (above it).
By their numbers in this assay, from the lowest: compound 3; then compounds 1 and 2 (each within the scatter of the next); then compound 4.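

On the carbonyl carbon next to the amide-type nitrogen, methoxy in place of cyclopentyl gives the first step read at this place in this assay, and it is large: a 13-fold higher number from compound 3 to compound 4 (1.10 log units; beyond the scatter). Replacing the carbamoyl groups gives a 5.0-fold higher number from compound 1 to compound 4 (0.70 log units; beyond the scatter) and a 2.5-fold higher number from compound 2 to compound 4 (0.40 log units; beyond the scatter), so (methoxycarbonyl)amino, unlike (cyclopentylcarbonyl)amino, stands on the weak side of both anilides. No measurement shown accounts for this step.

As far as these compounds go, whether the step follows the loss of the cyclopentyl ring or the entry of the methoxy oxygen stays open. A longer chain or a dimethylamino group on the same carbonyl carbon would bear on this.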